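A few compounds are considered here, and "the series" means these few. Any claim that something is new, unique, unknown or untested is made for them only; others in the source may bear on it.

Working notes on the series.

Going by the values given here, compound 1 `O=C(CSc1nc(Nc2ccccc2)c2ccccc2n1)Nc1ccccc1Cl` sits second highest of the three numbers so far: in a functional assay on NCI-H1975 cells (Homo sapiens) for inhibition, read by MTT assay, with a stated time of 72 h (a higher number here means a weaker inhibitor, a lower number a stronger inhibitor), compound 1 gives 9610 nM. Compound 2 `O=C(CSc1nc(Nc2ccccc2)c2ccccc2n1)Nc1ccccc1Br` gives 10300 nM, and the step of a 1.1-fold higher number from compound 1 to compound 2 (0.03 log units; within the scatter) is the nearest. Compound 3 `O=C(CSc1nc(Nc2ccccc2)c2ccccc2n1)Nc1cccc(F)c1` gives 6790 nM, the furthest from compound 1, with the step of a 1.4-fold lower number from compound 1 to compound 3 (0.15 log units; within the scatter); the related step of a 1.5-fold lower number from compound 2 to compound 3 (0.18 log units; within the scatter) is similar.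

Compound 4 `O=C(CSc1nc(Nc2ccccc2)c2ccccc2n1)Nc1ccc(C(F)(F)F)cc1` is not yet measured. The change from compound 1 is 4-(trifluoromethyl)phenyl in place of 2-chlorophenyl on an amide-type nitrogen.

The steps bearing on this are a 1.4-fold lower number from compound 1 to compound 3 (0.15 log units; within the scatter) and a 1.5-fold lower number from compound 2 to compound 3 (0.18 log units; within the scatter), both exchanges of the aryl group on the amide-type nitrogen, and neither reached beyond the scatter. No step beyond the scatter is therefore expected for compound 4, with the estimated step of a 1.1-fold lower number from compound 1 to compound 4 (0.05 log units; within the scatter). The estimate for compound 4 is 8500 nM, within the range 3000 nM to 25000 nM.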

Compound 4, half-maximal inhibitory concentration: 11700 nM
Estimate against measurement, compound 4: 1.4-fold (0.14 log units) below; measured number inside the range.
By their numbers in this assay, from the lowest: compounds 3, 1, 2 and 4 (each within the scatter of the next).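

The 4-(trifluoromethyl)phenyl group brings 10 heavy atoms to the amide-type nitrogen in place of the 7 of 2-chlorophenyl, yet every new step stays within the scatter (a 1.2-fold higher number from compound 1 to compound 4 (0.09 log units; within the scatter); a 1.1-fold higher number from compound 2 to compound 4 (0.06 log units; within the scatter); a 1.7-fold higher number from compound 3 to compound 4 (0.24 log units; within the scatter)). All four aryl groups at this position therefore give numbers that cannot be told apart in this assay. No evidence on the reason is available.

From the compounds shown here alone, whether an amine, a carboxylic acid or a longer chain in place of the aryl group would give a step beyond the scatter remains open. Going by these compounds, the effect of changes to the shared core also remains open.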